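Methoxy for fluoro on the aryl ketone: cytotoxicity notes

The compounds below may be only part of what the source reports. "The series", "measured", "known", "first", "only" and "open" are said of these compounds alone.

Compound 1 `CC(C)c1c(Cc2c(Cl)cccc2Cl)nc(SCC(=O)c2ccc(F)cc2)[nH]c1=O` was tested in an ADME assay on MT4 cells (Homo sapiens) for cytotoxicity, read by MTT assay; a higher number here means that more compound is tolerated, a lower number that less compound is tolerated. Compound 1 gives only a limit there, > 54000 nM. Compound 2 `COc1ccc(C(=O)CSc2nc(Cc3c(Cl)cccc3Cl)c(C(C)C)c(=O)[nH]2)cc1` differs from it by methoxy in place of fluoro on an aromatic carbon. Compound 2 likewise gives only a limit, > 14000 nM. The step that the two limits leave unreadable from compound 1 to compound 2 cannot be read because the limit of > 54000 nM in this assay, at which 1 of the 3 values shown sits, and the limit of > 14000 nM in this assay, at which 1 of the 3 values shown sits, cap both values.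

Compound 3 `Cc1c(Cc2c(F)cccc2F)nc(SCC(=O)c2ccc(F)cc2)[nH]c1=O` carries a different core; the difference between the two cores is not broken down here. Compound 3 gives only a limit, > 62000 nM, consistent with the limit of > 62000 nM in this assay, at which 1 of the 3 values shown sits. Compound 4 `COc1ccc(C(=O)CSc2nc(Cc3c(F)cccc3F)c(C)c(=O)[nH]2)cc1` differs from compound 3 by methoxy in place of fluoro on an aromatic carbon, the same change at the same place as from compound 1 to compound 2.

The step of an at least 1.2-fold lower number from compound 3 to compound 4 (0.09 log units; that floor lies within the scatter) is expected to stay within scatter, resting on the unreadable step that the two limits leave unreadable from compound 1 to compound 2 where both ends sit at limits. For compound 4 the value is estimated at 50000 nM, most likely reported again as a limit.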

Compound 4, half-maximal cytotoxic concentration: > 60000 nM
Compound 4: a limit, no number (the forecaster's own chance of this, stated with the estimate: 85%); middle value at least 1.2-fold (0.07 log units) from the limit.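

In this assay compound 4 gives only a limit, > 60000 nM. Within the data shown here, compound 3 also gives only a limit, > 62000 nM, and no step from compound 3 to compound 4 can be read. The compounds shown leave open whether methoxy in place of fluoro alters cytotoxicity at all.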